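The source may report more compounds than this note shows. Statements on the series, on what has been measured and on what is new or still open speak of the compounds shown alone.

Values in a functional assay on HeLa cells (Homo sapiens) for inhibition, read by MTT assay, with a stated time of 72 h; on this read-out higher numbers stand for weaker inhibition and lower numbers for stronger inhibition:
- compound 1 `COc1cc(NC(C)CCCNC(=O)Nc2ccc(F)cc2)c2ncccc2c1`: 20000 nM
- compound 2 `COc1cc(NC(C)CCCNC(=O)NNC(=O)Nc2ccc(Br)cc2)c2ncccc2c1`: 101000 nM
- compound 3 `COc1cc(NC(C)CCCNC(=O)NNC(=O)Nc2cccc(F)c2)c2ncccc2c1`: > 250000 nM, a limit and not a number

Compound 3 has no measured number and stands at the limit of > 250000 nM in this assay, at which 1 of the 3 values shown sits. Compound 4 `COc1cc(NC(C)CCCNC(=O)NNC(=O)Nc2ccc(O)cc2)c2ncccc2c1` differs from it by one exchange, 4-hydroxyphenyl in place of 3-fluorophenyl on an amide-type nitrogen.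

Two measured steps show the longer chain that compound 4 keeps, a 5.1-fold higher number from compound 1 to compound 2 (0.70 log units; beyond the scatter) and an at least 12-fold higher number from compound 1 to compound 3 (1.09 log units; beyond the scatter). Both go toward weaker inhibition, so nothing near compound 1 is expected. Among the compounds with values here, the closest precedent is the exchange at the same place, an at least 2.4-fold higher number from compound 2 to compound 3 (0.39 log units; beyond the scatter). Within the data shown here, only two groups have been measured there, so this is thin ground. On that precedent, a modest move toward stronger inhibition in this assay is expected, although a second limit reading remains quite possible. The expected change is an at least 1.6-fold lower number from compound 3 to compound 4 (0.22 log units; that floor lies within the scatter). For compound 4 the estimated value is 150000 nM, with an expected range of 60000 nM to 300000 nM.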

Compound 4, half-maximal inhibitory concentration: 85000 nM
For compound 4 the middle estimate is 1.8-fold (0.25 log units) above the measured one; the measured number falls inside the stated range.
By their numbers in this assay, from the lowest: compound 1; then compounds 4 and 2 (each within the scatter of the next). At a limit, above all of these: compound 3.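

In this assay, exchanging the group on this amide-type nitrogen brings the longer-chain series back to a measurable reading, an at least 2.9-fold lower number from compound 3 to compound 4 (0.46 log units; beyond the scatter), though the size of this change has only a floor. Compound 3 remains a limit and not a number: the limit of > 250000 nM in this assay, at which 1 of the 4 values shown sits. Hydroxy and bromo on the aromatic carbon are not separated, a 1.2-fold lower number from compound 2 to compound 4 (0.07 log units; within the scatter), and the recovery stops short of the shorter urea, a 4.3-fold higher number from compound 1 to compound 4 (0.63 log units; beyond the scatter).

Going by these compounds, that last step joins the longer chain and the change of ring group in one exchange, so the share of each stays open. On these data alone, how an amine or a carboxylic acid in place of the hydroxy on the aromatic carbon would read in this assay also stays open.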